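Compound 3 to compound 4: iodo for trifluoromethyl

The source may report more compounds than this note shows. Statements on the series, on what has been measured and on what is new or still open speak of the compounds shown alone.

Values measured in a functional assay on MCF7 cells (Homo sapiens) for cytotoxicity, read by MTT assay, with a stated time of 24 h (a higher number here means a weaker inhibitor, a lower number a stronger inhibitor), are as follows:
- compound 1 `COc1cc2ncnc(Nc3cccc(C(F)(F)F)c3)c2cc1OCCCSc1nc2ccccc2s1` gives 4050 nM
- compound 2 `COc1cc2ncnc(Nc3cccc(C(F)(F)F)c3)c2cc1OCCCSc1nc2ccccc2o1` gives 4030 nM
- compound 3 `CCCCc1nc(Cl)c(CO)n1CCCOc1cc2c(Nc3cccc(C(F)(F)F)c3)ncnc2cc1OC` gives 8280 nM

Compound 3 has the highest number of the three at 8280 nM and is the weakest member of this small set in this assay. Compound 4 `CCCCc1nc(Cl)c(CO)n1CCCOc1cc2c(Nc3cccc(I)c3)ncnc2cc1OC` has not yet been measured. Its difference from compound 3 is iodo in place of trifluoromethyl on an aromatic carbon, which is iodo in place of trifluoromethyl on an aromatic carbon, meta to a large group.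

Among the measured compounds shown here, none of the measured steps touches the 3-(trifluoromethyl)phenyl group, so the data offer no direct precedent for this exchange. They show only how far the numbers move when other parts change. One such change gives a 1.0-fold lower number from compound 1 to compound 2 (0.00 log units; within the scatter). Two others give a 2.0-fold higher number from compound 1 to compound 3 (0.31 log units; beyond the scatter) and a 2.1-fold higher number from compound 2 to compound 3 (0.31 log units; beyond the scatter), both modest.

With no evidence for a direction, the expectation stays anchored on compound 3 at 8280 nM and allows a wide margin. The estimate means a 1.1-fold lower number from compound 3 to compound 4 (0.04 log units; within the scatter), and no shift beyond the scatter is expected. Compound 4 is estimated at 7500 nM, with an expected range from 3000 nM to 18000 nM.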

Compound 4, half-maximal inhibitory concentration: 9950 nM
Compound 4: middle estimate off by 1.3-fold (0.12 log units), on the low side; the range from low to high includes it.
By their numbers in this assay, from the lowest: compounds 2 and 1 (each within the scatter of the next); then compounds 3 and 4 (each within the scatter of the next).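

Among the compounds shown here, the only direct reading at this position is the exchange of 3-(trifluoromethyl)phenyl for 3-iodophenyl, which in this assay gives a 1.2-fold higher number from compound 3 to compound 4 (0.08 log units; within the scatter) and so does not separate the two groups on this side chain. Neither group carries a hydrogen-bond donor or acceptor, and with the 2-butyl-4-chloro-5-(hydroxymethyl)-1H-imidazol-1-yl chain end in place, iodo serves as well as trifluoromethyl at this aromatic carbon, without a gain or a loss beyond the scatter. Nothing in hand gives a reason for this parity, and the reading rests on this single pair of compounds.

Still open, as far as these compounds go, is whether iodo in place of trifluoromethyl reads the same with the (1,3-benzothiazol-2-yl)sulfanyl or (1,3-benzoxazol-2-yl)sulfanyl chain ends of compound 1 and compound 2. Also open, from the compounds shown here alone, is whether any group on this aromatic carbon moves the number beyond the scatter, for instance an amine, a carboxylic acid, a nitrile or a longer alkyl chain, or whether the position tolerates such groups as it does these two.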